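Replacing 2,3-dichlorophenyl in compound 3: notes towards compound 4

The source may hold more compounds than are shown below. What is called first, only, known or untested is meant among the compounds shown, and "the series" means these compounds.

Measured in a functional assay on SW-620 cells (Homo sapiens) for cytotoxicity, read by MTT assay, with a stated time of 72 h; a higher number here means a weaker inhibitor, a lower number a stronger inhibitor:
- compound 1 `COc1cccc(/C=C2\CCC/C(=C\c3ccccc3Cl)C2=O)c1OC` gives 10300 nM
- compound 2 `COc1ccc(/C=C2\CCC/C(=C\c3cccc(OC)c3OC)C2=O)cc1` gives 13600 nM
- compound 3 `COc1cccc(/C=C2\CCC/C(=C\c3cccc(Cl)c3Cl)C2=O)c1OC` gives 16300 nM

Compound 3 (16300 nM) lies within the scatter of both compound 1 and compound 2, so the three cannot be ranked.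

Compound 4 `COc1cc(/C=C2\CCC/C(=C\c3cccc(OC)c3OC)C2=O)ccc1O` carries 4-hydroxy-3-methoxyphenyl in place of 2,3-dichlorophenyl on a double-bonded chain carbon bound to a double-bonded ring carbon and otherwise matches compound 3.

Among the measured compounds shown here, three measured steps bear on this change. Exchanges at the same place gave a 1.2-fold higher number from compound 2 to compound 3 (0.08 log units; within the scatter) and a 1.3-fold higher number from compound 1 to compound 2 (0.12 log units; within the scatter) and the added chloro gave a 1.6-fold higher number from compound 1 to compound 3 (0.20 log units; within the scatter) and all three stay within the scatter. For the measured compounds named here, no measured compound carries a hydroxy group, so that part of the change remains untested.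

No step beyond the scatter is therefore expected in this assay in either direction. The expected step is a 1.5-fold lower number from compound 3 to compound 4 (0.17 log units; within the scatter) and it remains only an estimate. Compound 4 is estimated at 11000 nM with a range of 4500 nM to 22000 nM and this range is kept wide for the untested hydroxy group.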

Compound 4, half-maximal inhibitory concentration: 8600 nM
Compound 4: middle estimate off by 1.3-fold (0.11 log units), on the high side, within the range that was stated.
By their numbers in this assay, from the lowest: compounds 4, 1, 2 and 3 (each within the scatter of the next).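

In this assay, the first group shown with a hydroxy at this place, on a double-bonded chain carbon bound to a double-bonded ring carbon, does not separate from the groups without one: 4-hydroxy-3-methoxyphenyl in place of 2,3-dichlorophenyl gives a 1.9-fold lower number from compound 3 to compound 4 (0.28 log units; within the scatter) and in place of 4-methoxyphenyl gives a 1.6-fold lower number from compound 2 to compound 4 (0.20 log units; within the scatter) and in place of 2-chlorophenyl gives a 1.2-fold lower number from compound 1 to compound 4 (0.08 log units; within the scatter). The exchange for 2,3-dichlorophenyl swaps a group with no hydrogen-bond donor or acceptor for one with both, and even this exchange of chlorine for oxygen stays within the scatter. No supporting measurement is available to explain this flat result.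

No pair shown differs by the hydroxy group alone, which leaves its separate contribution open. As far as these compounds go, all four compounds carry a substituted phenyl group at this place, and it remains open whether an amine or a carboxylic acid on that ring, or a longer chain in its stead, would give a step beyond the scatter.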